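Group on the ring nitrogen: three measured, one pending

The compounds below may be only part of what the source reports. "The series", "measured", "known", "first", "only" and "open" are said of these compounds alone.

Measured so far:
compound 1 `Nc1scc(CN2CCN(c3cc(Cl)cc(Cl)c3)CC2)c1C(=O)c1ccc(Cl)cc1` — 1%
compound 2 `Nc1scc(CN2CCN(c3cccnc3)CC2)c1C(=O)c1ccc(Cl)cc1` — 0%
compound 3 `Nc1scc(CN2CCN(c3ccccc3Cl)CC2)c1C(=O)c1ccc(Cl)cc1` — 0%

In an assay on CHO cells for displacement of a labelled ligand from adenosine receptor A3 (Homo sapiens), read by scintillation counting, with a stated time of 120 min, tested at 10 uM (a lower number here means less inhibition, a higher number more inhibition at the concentration tested (going by the name of the read-out)), compound 2 gives 0%; it stands level with compound 3 at the digits shown, the two together being the lowest of the three numbers, and the other step that ends at it is a number 1 percentage points lower from compound 1 to compound 2 (within the scatter). Compound 4 `Nc1scc(CN2CCN(c3ccc(Cl)c(Cl)c3)CC2)c1C(=O)c1ccc(Cl)cc1` differs from compound 2 by 3,4-dichlorophenyl in place of pyridin-3-yl on an amine nitrogen in a ring. For the measured compounds named here, the steps that bear on this exchange are a number 1 percentage points lower from compound 1 to compound 2 (within the scatter), which runs the opposite way between a dichlorophenyl and the pyridin-3-yl, and no change at the digits printed from compound 2 to compound 3 (within the scatter); both lie within the scatter, so every exchange of the group on this ring nitrogen seen so far leaves the read-out flat. The expected step is therefore a number 1 percentage points higher from compound 2 to compound 4 (within the scatter), none beyond the scatter. Compound 4 is estimated at 1%, within 0% to 8%.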

Compound 4, a percentage reported as inhibition, at one concentration (the size of the read-out at that concentration, not a potency): 3%
The estimate for compound 4 lay 2 percentage points below the measured number, and the stated range covers the measured number.
By their numbers in this assay, from the lowest: compounds 2, 3, 1 and 4 (each within the scatter of the next).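

In this assay, 3,4-dichlorophenyl on this amine nitrogen gives no step beyond the scatter against any other group: a number 3 percentage points higher from compound 2 to compound 4 (within the scatter) and a number 3 percentage points higher from compound 3 to compound 4 (within the scatter) and also a number 2 percentage points higher from compound 1 to compound 4 (within the scatter). The flat read-out at this position therefore extends to a second dichlorophenyl pattern, with 3,4-dichlorophenyl and 3,5-dichlorophenyl indistinguishable here. No available measurement points to a cause for this flatness.

Open, from the compounds shown here alone, is whether a non-aromatic group on this nitrogen, such as an acetyl group or a longer alkyl chain, moves the read-out beyond the scatter. Going by these compounds, a benzyl group, with a carbon linking the ring to the nitrogen, remains equally open.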